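Swapping an Aromatic Ring for a Branched Chain

The compounds below may be only part of what the source reports. "The series", "measured", "known", "first", "only" and "open" are said of these compounds alone.

Compound 1 `CC(C)CCn1nc(-c2ccn(C)c2)c(O)c(C2=NS(=O)(=O)c3cc(NS(C)(=O)=O)ccc3N2)c1=O` was tested in an in vitro ADME assay on microsomes from liver (Homo sapiens) for metabolic stability, tested at 5 uM (on this read-out lower numbers stand for a shorter-lived compound and higher numbers for a longer-lived compound), where compound 1 gives 0.633 h, the second highest of three numbers. Compound 3 `CC(C)CCn1nc(C2=CCCC2)c(O)c(C2=NS(=O)(=O)c3cc(NS(C)(=O)=O)ccc3N2)c1=O` gives 0.933 h in this assay, and a 1.5-fold higher number from compound 1 to compound 3 (0.17 log units; within the scatter). Compound 2 `CC(C)CCn1nc(C2CCCC2)c(O)c(C2=NS(=O)(=O)c3cc(NS(C)(=O)=O)ccc3N2)c1=O` gives 0.283 h. Compound 4 `CCC(C)(C)c1nn(CCC(C)C)c(=O)c(C2=NS(=O)(=O)c3cc(NS(C)(=O)=O)ccc3N2)c1O` differs from compound 1 by 1,1-dimethylpropyl in place of 1-methyl-1H-pyrrol-3-yl on an aromatic carbon: a five-membered aromatic ring leaves and a chain with no ring enters. The step that bears on this is a 2.2-fold lower number from compound 1 to compound 2 (0.35 log units; beyond the scatter), where a ring with no aromatic character likewise replaced the aromatic ring; a 3.3-fold higher number from compound 2 to compound 3 (0.52 log units; beyond the scatter) separates the two non-aromatic ring variants. A modest fall is therefore expected, a 1.8-fold lower number from compound 1 to compound 4 (0.26 log units; within the scatter). Compound 4 is estimated at 0.35 h, with a range from 0.15 h to 0.8 h.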

Compound 4, half-life: 0.1 h
Compound 4: middle estimate off by 3.5-fold (0.54 log units), on the high side; the measured number lies below the stated range.
By their numbers in this assay, from the lowest: compound 4; then compound 2; then compounds 1 and 3 (each within the scatter of the next).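

In this assay compound 4, with its 1,1-dimethylpropyl chain, gives the lowest number of the four, beyond the scatter against 1-methyl-1H-pyrrol-3-yl (a 6.3-fold lower number from compound 1 to compound 4 (0.80 log units; beyond the scatter)), cyclopent-1-en-1-yl (a 9.3-fold lower number from compound 3 to compound 4 (0.97 log units; beyond the scatter)) and cyclopentyl (a 2.8-fold lower number from compound 2 to compound 4 (0.45 log units; beyond the scatter)). At this position, then, a group with no ring goes lower than any of the three rings, including the saturated cyclopentyl, which until now marked the bottom of the series. On these data alone, whether an unbranched chain, or a chain ending in an amine, would fall as far stays open. Nothing measured here says why the number drops.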